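Swapping an ester for an allyl group on the core

The source may report more compounds than this note shows. Statements on the series, on what has been measured and on what is new or still open speak of the compounds shown alone.

Of the compounds shown here, two have been measured so far in a functional assay on ECV-304 cells (Homo sapiens), read by MTT assay, with stated times of 24 h and 12 h, tested at 25 uM; a lower number here means a weaker effect, a higher number a stronger effect of the compound at the concentration tested. Compound 1, with the structure `COC(=O)c1ccc(OCc2nc(C)c(C)nc2C)c(OC)c1`, gives 15.5% in this assay. Compound 2, with the structure `Cc1nc(C)c(COC(=O)CCCC[C@@H]2CCSS2)nc1C`, gives 71.4% in this assay. Of the two numbers, compound 1 stands lowest, and the gap between compound 1 and compound 2 is larger than the usual scatter of such measurements. Compound 2 is built quite differently, so its number says little about what a small change to compound 1 will do.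

Compound 3, with the structure `C=CCc1ccc(OCc2nc(C)c(C)nc2C)c(OC)c1`, is the compound not yet measured. It differs from compound 1 in one place: allyl in place of methoxycarbonyl on an aromatic carbon. Among the measured compounds shown here, nothing measured so far shows how this assay answers to this particular change on this core, so the direction of the step is uncertain. The expectation is a modest step, estimated as a number 6.5 percentage points higher from compound 1 to compound 3 (within the scatter), that may well stay within the scatter. Compound 3 is therefore expected to give about 22% in this assay, within a range from 5% to 48%.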

Compound 3, a percentage reported as activity, at one concentration (the size of the read-out at that concentration, not a potency): 28.2%
Beside the measured number, compound 3's estimate is 6.2 percentage points below it; the range from low to high includes it.
By their numbers in this assay, from the lowest: compound 1; then compound 3; then compound 2.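

Placing allyl in place of methoxycarbonyl on this aromatic carbon gives, in this assay, a number 12.7 percentage points higher from compound 1 to compound 3 (beyond the scatter), a modest step. Compound 2 is built too differently to show how this position behaves, whereas this pair shows that a change at this one place, para to a large group and meta to a methoxy group, can move the read-out beyond the usual scatter. It also shows that the hydrogen-bond acceptors of the methoxycarbonyl group are not needed to keep the effect at this level, since allyl has none, but no measurement of any property accompanies this pair, and the data offer no explanation for the step.

As far as these compounds go, a single swap gives one step and no trend, so it remains open whether the double bond of the allyl group matters, which a saturated propyl chain in the same place would help to answer. From the compounds shown here alone, it is also open whether a carboxylic acid, an amine or a longer chain at this position would raise the number further or bring it back down.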